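Fluoro for methyl on a sulfonyl ring: a second look

The compounds below may be only part of what the source reports. "The series", "measured", "known", "first", "only" and "open" are said of these compounds alone.

Three measured compounds share one core. Compound 1 `Cc1ccc(S(=O)(=O)N2N=C(c3ccc(N4CCN(C)CC4)cc3)CC2c2ccc(N(C)C)cc2)cc1`, in a functional assay on NCI-H1975 cells (Homo sapiens) for inhibition, read by sulforhodamine B assay, tested at 10 uM (on this read-out higher numbers stand for more inhibition at the one concentration tested (going by the name of the read-out) and lower numbers for less inhibition), gives 38.1%. Compound 2 `CN1CCN(c2ccc(C3=NN(S(=O)(=O)c4ccc(F)cc4)C(c4ccc(N(C)C)cc4)C3)cc2)CC1` differs from compound 1 by fluoro in place of methyl on an aromatic carbon, and in this assay compound 2 gives 95.7%; the step of a number 57.6 percentage points higher from compound 1 to compound 2 (beyond the scatter). Compound 3 `Cc1ccc(S(=O)(=O)N2N=C(c3ccc(-n4cncn4)cc3)CC2c2ccc(N(C)C)cc2)cc1` differs from compound 1 by 1H-1,2,4-triazol-1-yl in place of 4-methylpiperazin-1-yl on an aromatic carbon, and in this assay compound 3 gives 20%, which is the lowest of the three numbers, with the step of a number 18.1 percentage points lower from compound 1 to compound 3 (beyond the scatter).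

Compound 4 `CN(C)c1ccc(C2CC(c3ccc(-n4cncn4)cc3)=NN2S(=O)(=O)c2ccc(F)cc2)cc1` has not been measured. It differs from compound 3 by fluoro in place of methyl on an aromatic carbon, the same change as that from compound 1 to compound 2, made on the core of compound 3 rather than that of compound 1; the two places are described in the same words. That change occurs twice among the compounds shown. Going by the values given here, whether it carries over is supported only by the single measured instance, so the expectation is tentative. Compound 4 is expected to rise by roughly a number 42 percentage points higher from compound 3 to compound 4 (beyond the scatter), a step somewhat smaller than the earlier one because compound 3 starts from 20% and the number in this assay has only so much room to go higher. Compound 4 is therefore estimated at 62%, most likely between 30% and 90%.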

Compound 4, a percentage reported as inhibition, at one concentration (the size of the read-out at that concentration, not a potency): -0.5%
Compound 4: the middle estimate sits 62.5 percentage points above what was measured; measured number below the stated range.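

Carried to the core of compound 3, fluoro in place of methyl gave, in this assay, a number 20.5 percentage points lower from compound 3 to compound 4 (beyond the scatter), so the same change went in opposite directions on the two cores: the same change on two cores in this assay, a number 57.6 percentage points higher (beyond the scatter) from compound 1 to compound 2 and a number 20.5 percentage points lower (beyond the scatter) from compound 3 to compound 4, 78.1 percentage points apart, beyond the scatter of two such steps

Read from the other side of the same square, 1H-1,2,4-triazol-1-yl in place of 4-methylpiperazin-1-yl gave a number 96.2 percentage points lower from compound 2 to compound 4 (beyond the scatter), a far larger drop than the earlier one: the same change on two cores in this assay, a number 18.1 percentage points lower (beyond the scatter) from compound 1 to compound 3 and a number 96.2 percentage points lower (beyond the scatter) from compound 2 to compound 4, 78.1 percentage points apart, beyond the scatter of two such steps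

The four compounds therefore show that the two changes do not simply add in this series, and that the step from 4-methylphenyl to 4-fluorophenyl cannot be carried from the core of compound 1 to the core of compound 3, but with only these two instances they do not show why, nor how that step would behave on any other core.

The compounds shown leave open whether the rise seen with fluoro depends on the 4-methylpiperazin-1-yl group itself or would also appear with another amine, such as morpholine or piperidine, in that place. They also leave open whether a chloro or methoxy group on the sulfonyl ring would follow fluoro or methyl, and, with a single concentration tested, how these numbers relate to potency.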